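Cytotoxicity notes: from isobutyl to pyridin-2-yl

This account rests on a few compounds, and the source may have more. Where it says the series, first, only, none or still open, it means among the compounds named here.

Compound 1 `Brc1ccc(Cn2ccc3nc(-c4ccccc4)nc-3c2)cc1`: 83000 nM
Compound 2 `CC(C)CCn1ccc2nc(-c3ccccc3)nc-2c1`: > 100000 nM

Both values come from an ADME assay on MDBK cells (Bos taurus) for cytotoxicity; on this read-out higher numbers stand for lower toxicity in this test and lower numbers for higher toxicity in this test. Compound 2 stands at > 100000 nM, which is a limit of the assay and not a number.

Compound 3 `c1ccc(-c2nc3ccn(Cc4ccccn4)cc-3n2)cc1` is the next case. The change is pyridin-2-yl in place of isobutyl on a saturated chain carbon bound to an aromatic nitrogen, in words pyridin-2-yl in place of isobutyl on a saturated chain carbon bound to an aromatic nitrogen.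

Going by the values given here, only one measured step bears on this place: an at least 1.2-fold higher number from compound 1 to compound 2 (0.08 log units; that floor lies within the scatter). It is the swap of isobutyl for 4-bromophenyl, so it also involves an aromatic six-membered ring, though not the same one. Compound 1, which carries that ring, gives 83000 nM. No step beyond the scatter is expected in this assay because an at least 1.2-fold higher number from compound 1 to compound 2 (0.08 log units; that floor lies within the scatter) is all that has been measured here, and this one step is thin support. The assay may well report only a limit again.

The estimated step is an at least 1.1-fold lower number from compound 2 to compound 3 (0.04 log units; that floor lies within the scatter). For compound 3 the expected value is 90000 nM, with an estimated range of 45000 nM to 130000 nM.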

Compound 3, half-maximal cytotoxic concentration: > 100000 nM
Compound 3 was reported as a limit; the forecaster's own chance of this, stated with the estimate: 60%; at least 1.1-fold (0.04 log units) between middle value and limit.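

In this assay, compound 3 gives > 100000 nM, which is a limit of the assay and not a number. Exchanging the 4-bromophenyl group for pyridin-2-yl gives an at least 1.2-fold higher number from compound 1 to compound 3 (0.08 log units; that floor lies within the scatter), so this second comparison with compound 1 again yields only a floor and no firm gap. The steps between the limit-bound compounds cannot be read, and isobutyl and pyridin-2-yl cannot be ranked at this position because both results rest on the same limit: the limit of > 100000 nM in this assay, at which 2 of the 3 values shown sit.

On these data alone, compound 1 remains the only one of the three with a number in this assay, and the distance of compound 2 and compound 3 from any measurable cytotoxic concentration stays open. Also open, as far as these compounds go, is whether a primary amine, a carboxylic acid or a longer chain on a saturated chain carbon bound to an aromatic nitrogen would give a number in this assay or another limit.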